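A Cyclopropylsulfonyl Group in Place of Acetyl: Compound 4

The source may hold more compounds than are shown below. What is called first, only, known or untested is meant among the compounds shown, and "the series" means these compounds.

Measured so far in a functional assay on HCC1806 cells (Homo sapiens) for inhibition, read by sulforhodamine B assay, tested at 10 uM; on this read-out higher numbers stand for more inhibition at the one concentration tested (going by the name of the read-out) and lower numbers for less inhibition:
Compound 1 `CC(=O)N1N=C(c2ccc(N3CCN(C)CC3)cc2)CC1c1ccc(N(C)C)cc1` gives -0.8%.
Compound 2 `Cc1ccc(C(=O)N2N=C(c3ccc(N4CCN(C)CC4)cc3)CC2c2ccc(N(C)C)cc2)cc1` gives -2.5%.
Compound 3 `CN1CCN(c2ccc(C3=NN(S(C)(=O)=O)C(c4ccc(N(C)C)cc4)C3)cc2)CC1` gives -18.5%.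

Compound 1 holds the highest of the three numbers in this assay; compound 2 lies within the scatter of it, with a number 1.7 percentage points lower from compound 1 to compound 2 (within the scatter), whereas compound 3 lies beyond it, with a number 17.7 percentage points lower from compound 1 to compound 3 (beyond the scatter). Compound 4 `CN1CCN(c2ccc(C3=NN(S(=O)(=O)C4CC4)C(c4ccc(N(C)C)cc4)C3)cc2)CC1` differs from compound 1 in one place: cyclopropylsulfonyl in place of acetyl on an amine nitrogen in a ring. Among the compounds with values here, two measured steps bear on this change, each replacing a carbonyl-bearing group on an amine nitrogen in a ring with methylsulfonyl: a number 17.7 percentage points lower from compound 1 to compound 3 (beyond the scatter) and a number 16 percentage points lower from compound 2 to compound 3 (beyond the scatter). Cyclopropylsulfonyl is not methylsulfonyl, so the parallel is loose, but the sulfonyl for acetyl exchange is shared. Compound 4 is therefore expected to show a lower number, a step of about a number 14.2 percentage points lower from compound 1 to compound 4 (beyond the scatter), to an estimated -15% with a range from -30% to 0%.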

Compound 4, a percentage reported as inhibition, at one concentration (the size of the read-out at that concentration, not a potency): 4.7%
The estimate for compound 4 lay 19.7 percentage points below the measured number; the whole stated range lies below it.
By their numbers in this assay, from the lowest: compound 3; then compounds 2, 1 and 4 (each within the scatter of the next).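

In this assay, a sulfonyl group on this ring nitrogen does not by itself lower the number: cyclopropylsulfonyl in place of acetyl gives only a small step (a number 5.5 percentage points higher from compound 1 to compound 4 (within the scatter)), as it does in place of (4-methylphenyl)carbonyl (a number 7.2 percentage points higher from compound 2 to compound 4 (within the scatter)). What sits on the sulfonyl sulfur therefore matters, with cyclopropyl in place of methyl giving a larger step (a number 23.2 percentage points higher from compound 3 to compound 4 (beyond the scatter)). No evidence is at hand to explain this difference.

On these data alone, it remains open whether the ring itself or simply the added carbons account for this step, which an ethyl or isopropyl group on the sulfur could separate. Also open, as far as these compounds go, is whether any group here, such as a phenylsulfonyl, would lift the number clearly beyond the scatter of compound 1.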